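Replacing Isobutylsulfanyl with Butoxy on a Shared Core

The compounds below may be only part of what the source reports. "The series", "measured", "known", "first", "only" and "open" are said of these compounds alone.

Compound 1 `CC(C)CSc1nc(N)nc2c1ncn2/C=C1/CC1(CO)CO` — > 300000 nM
Compound 2 `CCCNc1nc(N)nc2c1ncn2/C=C1/CC1(CO)CO` — > 300000 nM
Compound 3 `CCOc1nc(N)nc2c1ncn2/C=C1/CC1(CO)CO` — > 300000 nM

Three measured compounds share one core and differ only in the group on one aromatic carbon. In an ADME assay on HFF cells (Homo sapiens) for cytotoxicity, with a stated time of 8 days (on this read-out higher numbers stand for lower toxicity in this test and lower numbers for higher toxicity in this test), compound 1 is reported only as a limit, > 300000 nM. Compound 2 likewise stands at a limit in this assay, > 300000 nM. Compound 3 also sits at a limit in this assay, > 300000 nM. All three values share the same limit (the limit of > 300000 nM in this assay, at which 3 of the 3 values shown sit), so compound 1 cannot be ranked against the other two on these numbers.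

The step to compound 4 `CCCCOc1nc(N)nc2c1ncn2/C=C1/CC1(CO)CO` is butoxy in place of isobutylsulfanyl on an aromatic carbon. The two measured steps that start from compound 1 and remove the same isobutylsulfanyl group are a step that the two limits leave unreadable from compound 1 to compound 2 and a step that the two limits leave unreadable from compound 1 to compound 3; the step that the two limits leave unreadable from compound 2 to compound 3 between the two replacements is equally unreadable. With both ends of every measured step sitting at the limit, no direction and no size can be read, and nothing in the data sets compound 4 apart. Compound 4 is therefore expected to behave like compound 1, with an expected step that the limit leaves unreadable from compound 1 to compound 4, and most probably to be reported again only as a limit. Compound 4 is estimated at 400000 nM, with a range from 200000 nM to 900000 nM.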

Compound 4, half-maximal cytotoxic concentration: > 300000 nM
Compound 4 gave a limit, no number; the forecaster's own chance of this, stated with the estimate: 85%; the middle value lies beyond the limit too.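

In this assay compound 4 is reported only as a limit (> 300000 nM). Among the compounds shown here, no new step between compound 4 and compound 1, compound 2 or compound 3 can be read, as all four compounds stand at the same limit: the limit of > 300000 nM in this assay, at which 4 of the 4 values shown sit. The compounds shown leave open whether isobutylsulfanyl, propylamino, ethoxy and butoxy differ at all in cytotoxicity beyond that limit.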